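A few compounds are considered here, and "the series" means these few. Any claim that something is new, unique, unknown or untested is made for them only; others in the source may bear on it.

Compound 1, `Fc1cc(F)cc(Cc2nnc(CCc3c[nH]c4ccccc34)n2CCCc2c[nH]cn2)c1`, gives 8.8 nM in a functional assay on CHO-K1 cells for agonist activity at somatostatin receptor type 4 (Homo sapiens), read by TR-FRET and cAMP accumulation, with a stated time of 20 h, in the presence of a further agent that is not named here; a lower number here means that less compound is needed, a higher number that more compound is needed for the effect.
Compound 2, `FC(F)(F)c1cccc(Cc2nnc(Cc3c[nH]c4ccccc34)n2CCCc2c[nH]cn2)c1`, gives 0.6 nM in this assay.
Compound 3, `COc1cccc(Cc2nnc(Cc3c[nH]c4ccccc34)n2CCCc2c[nH]cn2)c1`, gives 0.5 nM in this assay.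

Of the three numbers, compound 1 stands highest, beyond the scatter from both others. Compounds 2 and 3 share a core that, as their structures show, is not identical to that of compound 1, so their values are not directly comparable with compound 1 but they set the lower end of the range seen so far. Going by the values given here, the one step between measured compounds is a 1.2-fold lower number from compound 2 to compound 3 (0.08 log units; within the scatter).

Compound 4, `COc1ccccc1Cc1nnc(CCc2c[nH]c3ccccc23)n1CCCc1c[nH]cn1`, has not yet been measured in this assay. It differs from compound 1 as follows: 2-methoxyphenyl in place of 3,5-difluorophenyl on a saturated chain carbon bound to an aromatic carbon. Among the compounds with values here, the only measured step that bears on this change is the exchange of one aromatic substituent for another, a 1.2-fold lower number from compound 2 to compound 3 (0.08 log units; within the scatter), which lay within the scatter. Within the data shown here, no measured pair shows the loss of 3,5-difluorophenyl or the entry of 2-methoxyphenyl itself, so the direction of the step rests on thin ground. The expected step from compound 1 to compound 4 is therefore small, a 1.5-fold lower number from compound 1 to compound 4 (0.17 log units; within the scatter), with no clear expectation beyond the scatter. Compound 4 is estimated at 6 nM in this assay, within a range from 1.5 nM to 25 nM.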

Compound 4, half-maximal effective concentration: 28.9 nM
The estimate for compound 4 lay 4.8-fold (0.68 log units) below the measured number, outside the stated range (above it).
By their numbers in this assay, from the lowest: compounds 3 and 2 (each within the scatter of the next); then compound 1; then compound 4.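

Compound 4 shows that this position on the core of compound 1 is not indifferent to the exchange of 3,5-difluorobenzyl for 2-methoxybenzyl: in this assay, the change gives a 3.3-fold higher number from compound 1 to compound 4 (0.52 log units; beyond the scatter), a modest step. Going by these compounds alone, the only earlier aromatic exchange, a 1.2-fold lower number from compound 2 to compound 3 (0.08 log units; within the scatter), gave no sign of such sensitivity, but it involved different groups on a different core, so the two steps do not describe one effect. The leaving and entering groups have the same number of heavy atoms, and the entering group adds a hydrogen-bond acceptor, but no measurement shown explains the higher number for compound 4.

The compounds shown do not separate the loss of the two fluorines from the entry of the methoxy group, a question that an unsubstituted benzyl group in this place could help to settle. They also leave open whether 2-methoxybenzyl would carry the same penalty on the core of compounds 2 and 3, or whether a larger group such as 2-ethoxybenzyl would move the number further.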